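The source may report more compounds than this note shows. Statements on the series, on what has been measured and on what is new or still open speak of the compounds shown alone.

Measured in a functional assay on A549 cells (Homo sapiens) for antiproliferative activity, read by MTT assay, with a stated time of 48 h; on this read-out higher numbers stand for weaker inhibition and lower numbers for stronger inhibition:
- compound 1 `O=C(/C=C/c1ccc(Cl)cc1)Nc1cc(-c2ccccc2)[nH]n1` gives 1390 nM
- compound 2 `O=C(/C=C/c1ccc(Br)cc1)Nc1cc(-c2ccccc2)[nH]n1` gives 1460 nM
- compound 3 `Cc1ccc(/C=C/C(=O)Nc2cc(-c3ccccc3)[nH]n2)cc1` gives 1770 nM

Compound 2, at 1460 nM, stands within the scatter of both other compounds. Compound 4 `Cc1ccc(-c2cc(NC(=O)/C=C/c3ccc(Br)cc3)n[nH]2)cc1` differs from it by methyl in place of hydrogen on an aromatic carbon, phenyl to 4-methylphenyl: methyl in place of hydrogen on an aromatic carbon. Among the measured compounds shown here, no measured step makes this change at this place, so the evidence is indirect. Substitutions at the other end of the molecule were small: a 1.1-fold higher number from compound 1 to compound 2 (0.02 log units; within the scatter), a 1.3-fold higher number from compound 1 to compound 3 (0.10 log units; within the scatter) and a 1.2-fold higher number from compound 2 to compound 3 (0.08 log units; within the scatter). On those steps, no shift beyond the scatter is expected, and the estimated step is a 1.0-fold higher number from compound 2 to compound 4 (0.01 log units; within the scatter). Compound 4 is expected at 1500 nM, with an estimated range of 700 nM to 3200 nM.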

Compound 4, half-maximal inhibitory concentration: 1590 nM
Estimate against measurement, compound 4: 1.1-fold (0.03 log units) below, and the stated range covers the measured number.
By their numbers in this assay, from the lowest: compounds 1, 2, 4 and 3 (each within the scatter of the next).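

In this assay, among the compounds shown here, the change from phenyl to 4-methylphenyl gives a 1.1-fold higher number from compound 2 to compound 4 (0.04 log units; within the scatter) on this ring, the first direct test of this position, as the earlier compounds varied only the other end of the molecule. A methyl here, para to a large group, thus leaves the number within the scatter. No measurement shown speaks to the reason for this result.

The compounds shown leave open whether an amine, a carboxylic acid or a longer chain at this position would also stay within the scatter.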